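From compound 3 to compound 4: an aryl swap

A few compounds are considered here, and "the series" means these few. Any claim that something is new, unique, unknown or untested is made for them only; others in the source may bear on it.

In a functional assay on MCF7 cells (Homo sapiens) for inhibition, read by MTT assay, with a stated time of 48 h (a lower number here means a stronger inhibitor, a higher number a weaker inhibitor), compound 1 `Oc1ccc(C(c2c[nH]c3ccc(Br)cc23)c2c[nH]c3ccc(Br)cc23)cc1` gives 3500 nM, compound 2 `COc1ccc(C(c2c[nH]c3ccc(Br)cc23)c2c[nH]c3ccc(Br)cc23)cc1OC` gives 7800 nM and compound 3 `COc1ccc(OC)c(C(c2c[nH]c3ccc(Br)cc23)c2c[nH]c3ccc(Br)cc23)c1` gives 2800 nM. Compound 3 therefore sits with compound 1, well clear of compound 2. The measured steps are a 1.3-fold lower number from compound 1 to compound 3 (0.10 log units; within the scatter), a 2.8-fold lower number from compound 2 to compound 3 (0.44 log units; beyond the scatter) and a 2.2-fold higher number from compound 1 to compound 2 (0.35 log units; beyond the scatter).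

Compound 4 `CN(C)c1ccc(C(c2c[nH]c3ccc(Br)cc23)c2c[nH]c3ccc(Br)cc23)cc1` carries 4-(dimethylamino)phenyl in place of 2,5-dimethoxyphenyl on a saturated chain carbon bound to two aromatic carbons. Going by the values given here, no measured step tests this group, so the three aryl swaps are the only guide, and none exceeds a modest size. A small upward move is expected, namely a 1.4-fold higher number from compound 3 to compound 4 (0.15 log units; within the scatter). Compound 4 is estimated at 4000 nM, with an expected range of 1800 nM to 9000 nM.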

Compound 4, half-maximal inhibitory concentration: 24900 nM
Compound 4: the middle estimate sits 6.2-fold (0.79 log units) below what was measured, outside the stated range (above it).
By their numbers in this assay, from the lowest: compounds 3 and 1 (each within the scatter of the next); then compound 2; then compound 4.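

In this assay, 4-(dimethylamino)phenyl on a saturated chain carbon bound to two aromatic carbons gives an 8.9-fold higher number from compound 3 to compound 4 (0.95 log units; beyond the scatter) and a 3.2-fold higher number from compound 2 to compound 4 (0.50 log units; beyond the scatter) and a 7.1-fold higher number from compound 1 to compound 4 (0.85 log units; beyond the scatter) and all three steps lie beyond the scatter. This position therefore tolerates less than the hydroxyphenyl and dimethoxyphenyl groups suggested, and compound 4 gives the highest number of the four. No evidence in hand bears on the reason for this loss.

On these data alone, whether the loss follows the dimethylamino group itself or any nitrogen substituent remains open. A 4-aminophenyl or 4-methoxyphenyl group at this place would bear on that question.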